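The compounds below may be only part of what the source reports. "The series", "measured", "known", "first", "only" and "open" are said of these compounds alone.

Two compounds of a shared core have a number in a physicochemical assay for lipophilicity, using the shake flask method, measured as octanol-water partition, with a stated time of 30 min, at pH 7.4; on this read-out higher numbers stand for higher lipophilicity and lower numbers for lower lipophilicity. Compound 1 `COCc1ccc(-c2ccc3nnc(C(N)=O)c(N[C@@H](C)c4ccn(C)n4)c3c2)cn1` gives 3 in this assay. Compound 2 `C[C@H](Nc1c(C(N)=O)nnc2ccc(-c3ccc(OCCCN(C)C)nc3)cc12)C1CCOCC1` gives 1.9 in this assay, the lower of the two numbers, and the gap between the two values lies beyond the usual scatter. Among the measured compounds shown here, no pair of measured compounds differs in one place only, so no single measured step is available to lean on.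

Compound 3 `C[C@H](Nc1c(C(N)=O)nnc2ccc(-c3ccc(OCCCN(C)C)nc3)cc12)c1ccn(C)n1` has not yet been measured in this assay. It arises from compound 2 by one change: 1-methyl-1H-pyrazol-3-yl in place of oxan-4-yl on a saturated chain carbon bound to a nitrogen on an aromatic ring and a saturated chain carbon. The group that leaves and the group that enters are of equal size in heavy atoms, one a saturated ring and the other an aromatic ring.

For the measured compounds named here, with no measured step for this kind of exchange, the expectation rests on the number of compound 2 alone, and the step from compound 2 to compound 3 is expected to be small, no change at the digits printed from compound 2 to compound 3 (within the scatter), not beyond the scatter in either direction. Compound 3 is therefore estimated to give 1.9 in this assay, with a range from 1.3 to 2.5.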

Compound 3, distribution coefficient: 1.7
Compound 3: the middle estimate sits 0.20 log units above what was measured; measured number inside the range.
By their numbers in this assay, from the lowest: compounds 3 and 2 (each within the scatter of the next); then compound 1.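

In this assay, replacing oxan-4-yl with 1-methyl-1H-pyrazol-3-yl on the saturated chain carbon gives a number 0.20 log units lower from compound 2 to compound 3 (within the scatter) and so, in this one pair, a saturated ring and an aromatic ring of equal heavy-atom count cannot be told apart at this position. Compound 3 also forms a one-place pair with compound 1, and placing 3-(dimethylamino)propoxy instead of methoxymethyl on the aromatic carbon gives a number 1.30 log units lower from compound 1 to compound 3 (beyond the scatter) as a large step, which shows that the exchange at the aromatic carbon, unlike the one at the chain carbon, moves the number beyond the scatter. Nothing measured here accounts for either step.

Going by these compounds, whether the exchange at the chain carbon stays as small with methoxymethyl on the aromatic carbon remains open, as does the outcome for a different group at the chain carbon, such as a phenyl ring. The compounds shown also leave open which part of 3-(dimethylamino)propoxy goes with the large step, a question that a plain propoxy chain without the amine or a shorter 2-(dimethylamino)ethoxy chain would bear on.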